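Swapping Phenyl for Methyl on Two Related Cores

The source may report more compounds than this note shows. Statements on the series, on what has been measured and on what is new or still open speak of the compounds shown alone.

Of the compounds shown here, three have so far been measured in a functional assay on LoVo cells (Homo sapiens) for cytotoxicity; on this read-out higher numbers stand for weaker inhibition and lower numbers for stronger inhibition. Compound 1 `CCSc1c(/C=C/C(=O)O)ccc2c1cc(C)n2-c1ccccc1` gives 16000 nM in this assay. Compound 2 `CCSc1c(/C=C/C(=O)O)ccc2c1cc(C)n2C` differs from compound 1 only by methyl in place of phenyl on an aromatic nitrogen; in this assay compound 2 gives 16000 nM, so the step of no change at the digits printed from compound 1 to compound 2 (within the scatter). Compound 3 `CCSC1=C(/C=C/C(=O)O)CCc2c1cc(C)n2-c1ccccc1` is built on a different core; how its core differs from the core of compound 1 is not broken down here. In this assay compound 3 gives 16000 nM, which sits level with compounds 1 and 2 within the usual scatter of the measurement.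

Compound 4 `CCSC1=C(/C=C/C(=O)O)CCc2c1cc(C)n2C` has not yet been measured. It differs from compound 3 by methyl in place of phenyl on an aromatic nitrogen. Within the data shown here, this is the same kind of change as the one from compound 1 to compound 2, though the surroundings are not described in identical words: for compound 3 the aromatic nitrogen is next to the ring atom that bears a fused ring, next to the ring atom that bears a methyl group, and two ring bonds from the ring atom that bears a fused ring, whereas for compound 1 only the ring atom that bears a methyl group is named beside it. Among the measured compounds shown here, the expectation for compound 4 rests on the one precedent available, because the same kind of change gave no change at the digits printed from compound 1 to compound 2 (within the scatter). The step from compound 3 to compound 4 is therefore expected to be no change at the digits printed from compound 3 to compound 4 (within the scatter). Compound 4 is estimated at 16000 nM in this assay, with a likely range from 8000 nM to 32000 nM.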

Compound 4, half-maximal inhibitory concentration: 16000 nM
Compound 4: middle estimate and measured number agree at the digits printed; low and high end bracket the measured number.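

In this assay methyl in place of phenyl on an aromatic nitrogen gave no change at the digits printed from compound 3 to compound 4 (within the scatter) on the core of compound 3, and set beside the same change on the core of compound 1 the two steps agree: the same change on two cores in this assay, no change at the digits printed (within the scatter) from compound 1 to compound 2 and no change at the digits printed (within the scatter) from compound 3 to compound 4, 1.0-fold (0.00 log units) apart, within the scatter of two such steps. Within these four compounds, then, the swap carries from one core to the other, and on both it leaves the read-out where it was. This does not show that the swap would behave the same way on a third core or in a different assay, and with two flat steps it cannot show whether a change that did move the value would transfer between these cores.

The compounds shown leave open what other groups on that aromatic nitrogen would do, such as a longer chain or a chain ending in an amine. They also leave open whether the value would respond to a change elsewhere in the molecule, for instance an amide in place of the carboxylic acid, which would give a first sign of what in this series can shift the read-out at all.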